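Aryl Amide Change in a Shared Core Series

The source may hold more compounds than are shown below. What is called first, only, known or untested is meant among the compounds shown, and "the series" means these compounds.

compound 1 `COc1ccc2nc(C)cc(NC(=O)C(=O)Nc3cc(C)cc(C)c3)c2c1`: > 100000 nM, a limit of the assay
compound 2 `COc1ccc2nc(C)cc(OCCNc3cc(C)cc(C)c3)c2c1`: 31600 nM
compound 3 `COc1ccc2nc(C)cc(OCC(=O)Nc3ccccc3)c2c1`: 39800 nM

In a toxicity assay on HepG2 cells (Homo sapiens) for inhibition, read by CellTiter-Glo, with a stated time of 48 h (on this read-out lower numbers stand for stronger inhibition and higher numbers for weaker inhibition), compound 3 holds the highest of the two numbers read, and its nearest neighbour is compound 2, whose number lies within the usual scatter of it. For compound 1 the assay reports only a limit (the limit of > 100000 nM in this assay, at which 1 of the 3 values shown sits). Compound 4 `COc1ccc2nc(C)cc(OCC(=O)Nc3ccc(Cl)c(OC)c3)c2c1` is not yet measured; it differs from compound 3 by 4-chloro-3-methoxyphenyl in place of phenyl on an amide-type nitrogen. Going by the values given here, no measured pair shows a change of this kind, so the step of a 1.4-fold lower number from compound 3 to compound 4 (0.15 log units; within the scatter) is expected to be small, at most a modest move toward a lower number. Compound 4 is estimated at 28000 nM, with a range from 9000 nM to 90000 nM.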

Compound 4, half-maximal inhibitory concentration: > 100000 nM
Compound 4 was reported as a limit; the forecaster's own chance of this, stated with the estimate: 20%; at least 3.5-fold (0.55 log units) between middle value and limit.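

In this assay, going by these compounds alone, 4-chloro-3-methoxyphenyl in place of phenyl on an amide-type nitrogen gives an at least 2.5-fold higher number from compound 3 to compound 4 (0.40 log units; beyond the scatter), the only step here that can be read, and it runs toward weaker inhibition. The group on this nitrogen therefore matters to the read-out in this series. Compound 4 is reported only as a limit, so the full size of the step is unknown: the limit of > 100000 nM in this assay, at which 2 of the 4 values shown sit.

The compounds shown leave open whether the chloro or the methoxy part accounts for the step, and how a phenyl carrying only one of them, or an amine, would read. Steps among the other compounds cannot be read, as they differ in more than one place.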